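The source may report more compounds than this note shows. Statements on the series, on what has been measured and on what is new or still open speak of the compounds shown alone.

Measured compounds in an assay on brain (strain Sprague-Dawley) for displacement of a labelled ligand from metabotropic glutamate receptor 5 (Rattus norvegicus), with a stated time of 45 min; on this read-out lower numbers stand for stronger inhibition and higher numbers for weaker inhibition:
compound 1 `Cc1cccc(C#CC2=C/C(=N/Oc3cccc(F)n3)CCC2)n1` — 46.8 nM
compound 2 `Fc1cccc(O/N=C2/C=C(C#Cc3ccccn3)CCC2)n1` — 9.15 nM
compound 3 `N#Cc1ccc(F)cc1O/N=C1/C=C(C#Cc2ccccn2)CCC1` — 73.4 nM

Compound 2 holds the lowest number of the three in this assay. Compound 1 stands nearest to it, the step of a 5.1-fold lower number from compound 1 to compound 2 (0.71 log units; beyond the scatter) lying beyond the scatter; compound 3 stands furthest, its gap to compound 2 also beyond the scatter.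

Compound 4 `FCCOCCO/N=C1/C=C(C#Cc2ccccn2)CCC1` awaits measurement. The change from compound 2 is 2-(2-fluoroethoxy)ethyl in place of 6-fluoropyridin-2-yl on an oxygen. For the measured compounds named here, the only measured step, a 5.1-fold lower number from compound 1 to compound 2 (0.71 log units; beyond the scatter), concerns the aromatic carbon on the alkyne side, not the oxygen, so it does not bear on this change. Going by the values given here, compound 2 and compound 3 differ in the group on that oxygen, and their two values show that a change at this place is felt, but both carry an aromatic ring there; no measured compound carries an open chain in this place. The chain is therefore expected to cost potency, a modest step of a 4.4-fold higher number from compound 2 to compound 4 (0.64 log units; beyond the scatter) toward a higher number. Compound 4 is estimated at 40 nM, within 10 nM to 200 nM.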

Compound 4, inhibition constant: 3.8 nM
Estimate against measurement, compound 4: 11-fold (1.02 log units) above; the whole stated range lies above it.
By their numbers in this assay, from the lowest: compound 4; then compound 2; then compounds 1 and 3 (each within the scatter of the next).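

At this oxygen in this assay, an aromatic ring is not needed: 2-(2-fluoroethoxy)ethyl in place of 6-fluoropyridin-2-yl gives a 2.4-fold lower number from compound 2 to compound 4 (0.38 log units; beyond the scatter), so compound 2 no longer holds the lowest number in the series. Until now only ring-bearing groups had been seen at this place, and the open chain extends the range of accepted groups to one with no ring, with the counted hydrogen-bond donors and acceptors of the group unchanged. Nothing measured on these compounds accounts for the size or direction of this step.

Going by these compounds, it remains open whether the gain belongs to the open chain as such, to its ether oxygen or to its terminal fluorine. A plain hexyl chain, a longer ether chain, or a chain ending in an amine in place of the fluorine would separate these possibilities.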